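This account rests on a few compounds, and the source may have more. Where it says the series, first, only, none or still open, it means among the compounds named here.

Measured in an ADME assay on Raji cells (Homo sapiens) for cytotoxicity, read by luminescence, with a stated time of 72 h; on this read-out higher numbers stand for an effect only at larger amounts of compound and lower numbers for an effect already at smaller amounts:
compound 1 `CCOC(=O)c1c(-c2cccc(F)c2)[nH]c2cc(OC)ccc2c1=O`: > 21500 nM
compound 2 `CCOC(=O)c1c(-c2cccc(OC)c2)[nH]c2cc(Cl)c(OC)cc2c1=O`: > 21500 nM
compound 3 `CCOC(=O)c1c(-c2cccc(F)c2)[nH]c2cc(OC)c(F)cc2c1=O`: > 21500 nM

Each of these entries is a limit of the assay and not a number. Compound 3 stands at > 21500 nM, which is a limit. It has no position within the series beyond that, and the whole picture so far is the limit of > 21500 nM in this assay, at which 3 of the 3 values shown sit.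

Compound 4 `CCOC(=O)c1c(-c2cccc(Oc3c(C)cccc3C)c2)[nH]c2cc(OC)c(F)cc2c1=O` is the next change, with 2,6-dimethylphenoxy in place of fluoro on an aromatic carbon, meta to a large group: 2,6-dimethylphenoxy in place of fluoro on an aromatic carbon. For the measured compounds named here, the only measured step on the shared core is a step that the two limits leave unreadable from compound 1 to compound 3. It is a fluoro in place of hydrogen on an aromatic carbon, a different change, and it offers no size to carry over. Going by the values given here, no measured compound carries the entering group, so the expectation rests on the limits alone. No step beyond the scatter is expected in this assay, and a further limit is the likeliest outcome. If a number does appear, it is expected on the side of smaller amounts, close to the top of the range. The estimated step is an at least 1.0-fold lower number from compound 3 to compound 4 (0.03 log units; that floor lies within the scatter). For compound 4 the expected value is 20000 nM, with an estimated range from 7000 nM to 30000 nM.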

Compound 4, half-maximal effective concentration: > 21500 nM
Compound 4 was reported as a limit; the forecaster's own chance of this, stated with the estimate: 70%; at least 1.0-fold (0.03 log units) between middle value and limit.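

In this assay compound 4 gives > 21500 nM, which is a limit and not a number. Compound 3 also stands at a limit, so no step from compound 3 to compound 4 can be read, and the series remains at one level: the limit of > 21500 nM in this assay, at which 4 of the 4 values shown sit.

The compounds shown leave open whether any change on the shared core yields a measurable value in this assay.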